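Aminothiadiazole to methyloxadiazole swap on a chromone thioether

The source may hold more compounds than are shown below. What is called first, only, known or untested is meant among the compounds shown, and "the series" means these compounds.

Measured so far:
compound 1 `Cc1nnc(SCc2coc3ccccc3c2=O)o1`: 4600 nM
compound 2 `Cc1ccc2oc(CSc3nnc(N)s3)cc(=O)c2c1`: > 25000 nM
compound 3 `Nc1nnc(SCc2coc3ccccc3c2=O)s1`: > 25000 nM

Compound 3 carries a 5-amino-1,3,4-thiadiazol-2-yl group on a sulfur attached to a saturated chain carbon. In a functional assay on MCF7 cells (Homo sapiens) for cytotoxicity, read by MTT assay, with a stated time of 72 h (on this read-out higher numbers stand for weaker inhibition and lower numbers for stronger inhibition), compound 3 gives > 25000 nM, which is a limit of the assay and not a number. Compound 1 differs from it by 5-methyl-1,3,4-oxadiazol-2-yl in place of 5-amino-1,3,4-thiadiazol-2-yl on a sulfur. In this assay compound 1 gives 4600 nM, and the step of an at least 5.4-fold lower number from compound 3 to compound 1 (0.73 log units; beyond the scatter) is beyond the scatter, although its exact size is open because of the limit of > 25000 nM in this assay, at which 2 of the 3 values shown sit.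

Compound 2 shares the aminothiadiazole thioether with compound 3 but sits on a different core; the difference between the two cores is not broken down here. In this assay compound 2 gives > 25000 nM, again a limit of the assay rather than a number.

Compound 4 `Cc1ccc2oc(CSc3nnc(C)o3)cc(=O)c2c1` has not yet been measured. It differs from compound 2 by 5-methyl-1,3,4-oxadiazol-2-yl in place of 5-amino-1,3,4-thiadiazol-2-yl on a sulfur, the same change as from compound 3 to compound 1, at the same place. On the strength of the step of an at least 5.4-fold lower number from compound 3 to compound 1 (0.73 log units; beyond the scatter), the step from compound 2 to compound 4 is expected to be of similar direction and size, an at least 5.0-fold lower number from compound 2 to compound 4 (0.69 log units; beyond the scatter), though its size can only be an estimate. For compound 4 in this assay the estimate is 5000 nM, with a range from 1800 nM to 15000 nM.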

Compound 4, half-maximal inhibitory concentration: > 25000 nM
Compound 4 ended at the assay's limit (the forecaster's own chance of this, stated with the estimate: 20%); at least 5.0-fold (0.69 log units) between middle value and limit.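

In this assay, compound 2 and compound 4 both sit at a limit of the assay and not at a number, so the step between them cannot be read: the limit of > 25000 nM in this assay, at which 3 of the 4 values shown sit.

The compounds shown leave open whether 5-methyl-1,3,4-oxadiazol-2-yl in place of 5-amino-1,3,4-thiadiazol-2-yl on a sulfur lowers the number on the core of compound 2, as it does on the core of compound 1.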